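A pyrrolidine for a morpholine on the thiocarbonyl carbon

A few compounds are considered here, and "the series" means these few. Any claim that something is new, unique, unknown or untested is made for them only; others in the source may bear on it.

Compound 1 `N/C(=N\NC(=S)N1CCOCC1)c1ccccn1` is the reference point of this small set. In a functional assay on MCF7 cells (Homo sapiens) for cytotoxicity, read by MTT assay, with a stated time of 72 h, tested at 100 uM (a lower number here means less inhibition of growth, a higher number more inhibition of growth at the concentration tested), compound 1 gives 81.6%, the highest of the three numbers recorded. Compound 3 `Cc1cccc(/C(N)=N/NC(=S)N2CCOCC2)n1` gives 74.7% in this assay, and the step of a number 6.9 percentage points lower from compound 1 to compound 3 (within the scatter) shows two numbers that cannot be told apart. Compound 2 `Cc1ccnc(/C(N)=N/NC(=S)N2CCOCC2)c1` gives 12.8%, and the step of a number 68.8 percentage points lower from compound 1 to compound 2 (beyond the scatter) is the one large movement in the set.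

Compound 4 `N/C(=N\NC(=S)N1CCCC1)c1ccccn1` differs from compound 1 by pyrrolidin-1-yl in place of morpholin-4-yl on a thiocarbonyl carbon. Neither of the two measured steps bears on this change: both exchange a hydrogen for a methyl on an aromatic carbon and leave the thiocarbonyl side untouched. Going by the values given here, the measured pairs show only that a single change can either leave this assay unchanged, as from compound 1 to compound 3, or move it a long way, as from compound 1 to compound 2. For the thiocarbonyl side no such guide exists. The step of a number 11.6 percentage points lower from compound 1 to compound 4 (beyond the scatter) is therefore expected to be small, as nothing measured points in either direction, but with a wide margin. Compound 4 is estimated at 70% in this assay, within a range from 35% to 95%.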

Compound 4, percent growth inhibition at one concentration: 74.9%
The estimate for compound 4 lay 4.9 percentage points below the measured number; the range from low to high includes it.
By their numbers in this assay, from the lowest: compound 2; then compounds 3, 4 and 1 (each within the scatter of the next).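

The thiocarbonyl side now has a measured step of its own: in this assay the step of a number 6.7 percentage points lower from compound 1 to compound 4 (within the scatter) leaves compound 1 and compound 4 indistinguishable, so pyrrolidin-1-yl can stand in place of morpholin-4-yl on a thiocarbonyl carbon without a detectable shift in this read-out. The exchange gives up the oxygen of morpholin-4-yl and turns a six-membered non-aromatic ring into a five-membered one, and at this single concentration neither difference registers, which the methyl steps on the aromatic carbon could not have shown. No measurement is available that explains why the two groups give such similar results.

From the compounds shown here alone, it remains open whether the same holds for other groups on the thiocarbonyl carbon, such as piperidin-1-yl, 4-methylpiperazin-1-yl or an open-chain dimethylamino group. Going by these compounds alone, it is also open whether pyrrolidin-1-yl would fare the same way on the methylated core of compound 2, the one change so far to give a large movement, seen in the step of a number 68.8 percentage points lower from compound 1 to compound 2 (beyond the scatter), since the two sides have been varied here only one at a time.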